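A few compounds are considered here, and "the series" means these few. Any claim that something is new, unique, unknown or untested is made for them only; others in the source may bear on it.

Compound 1 `CCN1CCN(C[C@H]2CN(c3ccc(-n4cc(-c5ccccn5)cn4)c(F)c3)C(=O)O2)CC1` gives 2.19 in a physicochemical assay for lipophilicity, read by HPLC, measured as octanol-water partition; on this read-out lower numbers stand for lower lipophilicity and higher numbers for higher lipophilicity. Compound 2 `O=C1CNC(=O)N1C[C@H]1CN(c2ccc(-n3cc(-c4ccccn4)cn3)c(F)c2)C(=O)O1` gives 1.25 in this assay.

Among the compounds with values here, compound 2 stands lowest of the two numbers, the only measured step being a number 0.94 log units lower from compound 1 to compound 2 (beyond the scatter). Compound 3 `CCC(=O)NC[C@H]1CN(c2ccc(-n3cc(-c4ccccn4)cn3)c(F)c2)C(=O)O1` differs from compound 2 by propanoylamino in place of 2,5-dioxoimidazolidin-1-yl on a saturated chain carbon bound to a saturated ring carbon. That single measured step bears only loosely on this change, since it swapped a different pair of groups, so in this assay a small rise, possibly not beyond the scatter, is expected for compound 3. Compound 3 is expected to give 1.6, between 1.2 and 2.1, an estimated step of a number 0.35 log units higher from compound 2 to compound 3 (beyond the scatter).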

Compound 3, partition coefficient: 2.2
For compound 3 the middle estimate is 0.60 log units below the measured one; the measured number lies above the stated range.
By their numbers in this assay, from the lowest: compound 2; then compounds 1 and 3 (each within the scatter of the next).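

In this assay, propanoylamino in place of 2,5-dioxoimidazolidin-1-yl on a saturated chain carbon bound to a saturated ring carbon gives a number 0.95 log units higher from compound 2 to compound 3 (beyond the scatter), a step beyond the scatter at this place. Propanoylamino in place of 4-ethylpiperazin-1-yl gives a number 0.01 log units higher from compound 1 to compound 3 (within the scatter), so among these three groups 2,5-dioxoimidazolidin-1-yl alone stands apart. On these data alone, what a longer chain such as butanoylamino, or a carboxylic acid, would give at this place remains open. Nothing available explains the difference between these groups.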